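The compounds below may be only part of what the source reports. "The series", "measured", "known", "first", "only" and "open" are said of these compounds alone.

Within the data shown here, compound 1 `CC(C)(C)c1cc(NC(=O)Nc2ccc(-c3cncc(Cl)n3)cc2)on1` and compound 2 `Nc1ccc(-c2cncc(Cl)n2)cc1` are the two measured members. In an assay on isolated protein for inhibition of high affinity nerve growth factor receptor (Homo sapiens), with a stated time of 60 min, tested at 20 uM (on this read-out lower numbers stand for less inhibition and higher numbers for more inhibition at the one concentration tested (going by the name of the read-out)), compound 1 gives 41.4%; in this assay compound 2 gives 47%. These two numbers lie within the scatter of each other, so compound 2 does not stand apart from compound 1 on the numbers shown. Compound 3 `Cn1cc(-c2cncc(-c3ccc(N)cc3)n2)cn1` is not yet measured; it differs from compound 2 by 1-methyl-1H-pyrazol-4-yl in place of chloro on an aromatic carbon. Among the measured compounds shown here, no measured pair shows how this change acts, so the step of a number 2 percentage points lower from compound 2 to compound 3 (within the scatter) is expected to be small and of uncertain direction, most likely none beyond the scatter. Compound 3 is therefore estimated at 45%, with a range from 20% to 70%.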

Compound 3, a percentage reported as inhibition, at one concentration (the size of the read-out at that concentration, not a potency): 46%
For compound 3 the middle estimate is 1 percentage points below the measured one; the measured number falls inside the stated range.
By their numbers in this assay, from the lowest: compounds 1, 3 and 2 (each within the scatter of the next).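

In this assay, among these compounds, 1-methyl-1H-pyrazol-4-yl in place of chloro, on the aromatic carbon next to the ring nitrogen, gives a number 1 percentage points lower from compound 2 to compound 3 (within the scatter) as the first reading of a change at this position. The position therefore carries a five-membered aromatic ring as well as a single chlorine, with no shift beyond the scatter. No available evidence bears on this result.

On these data alone, whether an amine or a carboxylic acid at this position would move the read-out remains open. Also open, as far as these compounds go, is whether 1-methyl-1H-pyrazol-4-yl in place of chloro would act the same way on compound 1 .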